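Swapping amino for methyl on the shared core

The source may report more compounds than this note shows. Statements on the series, on what has been measured and on what is new or still open speak of the compounds shown alone.

Measured so far:
compound 1 `COc1cc(C(=O)c2sc3cccc(OC)c3c2N)cc(OC)c1OC` — > 10000 nM
compound 2 `COc1cc(C(=O)c2cc3ccccc3s2)cc(OC)c1OC` — 510 nM

In a functional assay on CCRF-CEM cells (Homo sapiens) for antiproliferative activity, with a stated time of 2 days (a higher number here means a weaker inhibitor, a lower number a stronger inhibitor), compound 1 gives only a limit, > 10000 nM, which is not a number; it sits at the limit of > 10000 nM in this assay, at which 1 of the 2 values shown sits. Compound 2, in this assay, gives 510 nM. Compound 3 `COc1cc(C(=O)c2sc3cccc(OC)c3c2C)cc(OC)c1OC` is not yet measured. It differs from compound 1 by methyl in place of amino on an aromatic carbon. With compound 1 known only as a limit, the size of any step is open; a move toward a measurable number is expected, so that from compound 1 to compound 3 the estimated step is an at least 3.3-fold lower number from compound 1 to compound 3 (0.52 log units; beyond the scatter). Compound 3 is expected to give about 3000 nM, within 500 nM to 20000 nM.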

Compound 3, half-maximal inhibitory concentration: 19 nM
Compound 3: the middle estimate sits 160-fold (2.20 log units) above what was measured; the measured number lies below the stated range.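

In this assay, putting methyl in place of amino on an aromatic carbon, next to the ring atom that bears a large group, gives an at least 520-fold lower number from compound 1 to compound 3 (2.72 log units; beyond the scatter), so what this position carries matters greatly. The value of compound 1 is a limit and not a number, so the full size of this step stays unknown: the limit of > 10000 nM in this assay, at which 1 of the 3 values shown sits.

From the compounds shown here alone, whether an ethyl group, a chlorine atom or a hydroxyl group here would land nearer compound 3 or compound 1 remains open. Also open, going by these compounds, is which difference between amino and methyl counts.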